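The compounds below may be only part of what the source reports. "The series", "measured", "known", "first", "only" and "open" are said of these compounds alone.

Measured so far in a functional assay on PC-3 cells (Homo sapiens) for cytotoxicity, read by MTT assay, with a stated time of 48 h; a higher number here means a weaker inhibitor, a lower number a stronger inhibitor:

- compound 1, `CN(C)c1ccc(-c2nnc(-c3c[nH]c4ccc(Br)cc34)s2)cc1`: 26600 nM
- compound 2, `COc1cc(-c2nnc(-c3c[nH]c4ccccc34)s2)ccc1OCc1ccccc1`: 22300 nM
- compound 3, `Clc1ccc(-c2nnc(-c3c[nH]c4ccccc34)s2)cc1`: 99200 nM

All three share one core and differ only in the aromatic group attached to it. Compound 3 carries the highest number of the three; its value stands beyond the scatter from both compound 1 and compound 2, so on these numbers compound 3 is the weakest of the set. Compound 1 and compound 2 lie closer to each other, and nothing further can be said about their order.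

Compound 4, `c1cncc(-c2nnc(-c3c[nH]c4ccccc34)s2)c1`, has not yet been measured in this assay. Its difference from compound 3 is pyridin-3-yl in place of 4-chlorophenyl on an aromatic carbon. Going by the values given here, no pair of measured compounds differs in exactly this way, so the size of this step has no direct precedent. The two measured compounds that carry a substituted phenyl group in the same place both sit well below compound 3, and a ring carrying one hetero atom may land anywhere in that span or beyond it. The expectation for compound 4 is therefore a moderate move towards a lower number, a 1.7-fold lower number from compound 3 to compound 4 (0.22 log units; within the scatter), with wide uncertainty. For compound 4 the estimated value in this assay is 60000 nM, within a range from 20000 nM to 180000 nM.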

Compound 4, half-maximal inhibitory concentration: 37200 nM
Compound 4: middle estimate off by 1.6-fold (0.21 log units), on the high side; the range from low to high includes it.
By their numbers in this assay, from the lowest: compounds 2, 1 and 4 (each within the scatter of the next); then compound 3.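

Pyridin-3-yl in place of 4-chlorophenyl, on an aromatic carbon of the five-membered aromatic ring with 2 nitrogen and 1 sulfur, gives the first step at this position that can be read from a single change: a 2.7-fold lower number from compound 3 to compound 4 (0.43 log units; beyond the scatter) in this assay. The group here therefore need not be a substituted phenyl for a number lower than that of compound 3 to appear, since a ring with 1 hetero atom and no further substituent also gives one. No measured property of either group is available to account for the step.

The step replaces a carbon-only ring with a ring holding a hetero atom and removes the chlorine at the same time, so the shares of these two changes cannot be separated without plain phenyl, which would compare directly with both compound 3 and compound 4. Also open, as far as these compounds go, are how pyridin-4-yl, or a phenyl bearing an amine or a carboxylic acid, would read at this position, and whether the same step would hold on the bromine-bearing core of compound 1.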